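A pent-1-yn-1-yl chain on the shared core

A few compounds are considered here, and "the series" means these few. Any claim that something is new, unique, unknown or untested is made for them only; others in the source may bear on it.

- compound 1 `C=Cc1cn([C@H]2C[C@H](O)[C@@H](CO)O2)c(=O)[nH]c1=O` gives 14200 nM
- compound 2 `C=C(Cl)c1cn([C@H]2C[C@H](O)[C@@H](CO)O2)c(=O)[nH]c1=O` gives 1660 nM
- compound 3 `C[S+]([O-])c1cn([C@H]2C[C@H](O)[C@@H](CO)O2)c(=O)[nH]c1=O` gives > 200000 nM as a limit

In an ADME assay on L1210/0 cells (Mus musculus) for cytotoxicity, with a stated time of 48 h (on this read-out higher numbers stand for weaker inhibition and lower numbers for stronger inhibition), compound 3 has no number, only the limit (> 200000 nM). Compound 4 `CCCC#Cc1cn([C@H]2C[C@H](O)[C@@H](CO)O2)c(=O)[nH]c1=O` differs from it on the shared core: a group of 5 heavy atoms (5 carbon; no ring) in place of a group of 3 heavy atoms (1 carbon, 1 oxygen, 1 sulfur; no ring), on an aromatic carbon. The pent-1-yn-1-yl group that enters holds carbon only, as do the groups of compound 1 and compound 2.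

Among the compounds with values here, two measured steps bear most directly on this change, and both are large: an at least 14-fold higher number from compound 1 to compound 3 (1.14 log units; beyond the scatter) and an at least 120-fold higher number from compound 2 to compound 3 (2.08 log units; beyond the scatter). Read in reverse, they suggest a clearly lower number for compound 4. Within the data shown here, a third step, an 8.6-fold lower number from compound 1 to compound 2 (0.93 log units; beyond the scatter), shows that a change within such a carbon group can also shift the number, so the size remains uncertain, and no pent-1-yn-1-yl compound has been measured.

The expected step is an at least 4.0-fold lower number from compound 3 to compound 4 (0.60 log units; beyond the scatter), a rough figure since it starts from a limit. For compound 4 the estimate is 50000 nM, with an expected range from 12000 nM to 200000 nM.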

Compound 4, half-maximal inhibitory concentration: > 200000 nM
Compound 4 gave a limit, no number (the forecaster's own chance of this, stated with the estimate: 30%); at least 4.0-fold (0.60 log units) between middle value and limit.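

In this assay compound 4 gives only a limit, > 200000 nM, so a group of carbon alone on this aromatic carbon does not by itself bring the number down. The pent-1-yn-1-yl chain stands well apart from the vinyl and 1-chloroethenyl groups, with an at least 14-fold higher number from compound 1 to compound 4 (1.14 log units; beyond the scatter) and an at least 120-fold higher number from compound 2 to compound 4 (2.08 log units; beyond the scatter), so which carbon group sits at this position matters. The step between compound 3 and compound 4 cannot be read, since both sit at the same limit: the limit of > 200000 nM in this assay, at which 2 of the 4 values shown sit.

From the compounds shown here alone, it remains open whether the triple bond or the length of the chain goes with the higher number; an ethynyl group and a saturated pentyl chain at this position would separate the two. Going by these compounds, how far compound 3 and compound 4 lie beyond their limits also stays unknown.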